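Aryl swap on the sulfonamide nitrogen: from difluoro to methoxy

The source may report more compounds than this note shows. Statements on the series, on what has been measured and on what is new or still open speak of the compounds shown alone.

For the measured compounds named here, compound 2 `O=C1NCCN1c1ccc(S(=O)(=O)Nc2ccc(F)c(F)c2)cc1` gives 350 nM in a functional assay on HT-29 cells (Homo sapiens) for antiproliferative activity, read by sulforhodamine B assay, with a stated time of 48 h (on this read-out lower numbers stand for stronger inhibition and higher numbers for weaker inhibition), the higher of the two numbers so far; compound 1 `O=C1NCCN1c1ccc(S(=O)(=O)Nc2cccc(Br)c2)cc1` gives 77 nM. Going by the values given here, the one measured step, a 4.5-fold higher number from compound 1 to compound 2 (0.66 log units; beyond the scatter), shows that the aryl group on the sulfonamide nitrogen shifts the number by a modest amount. Compound 3 `COc1ccccc1NS(=O)(=O)c1ccc(N2CCNC2=O)cc1` changes that same group: 2-methoxyphenyl in place of 3,4-difluorophenyl on a sulfonamide nitrogen. Among the compounds with values here, no measured pair covers a methoxy-bearing aryl here, so only a change of the size already seen is expected, with direction uncertain. Compound 3 is estimated at 220 nM, in the range 60 nM to 800 nM, a step of a 1.6-fold lower number from compound 2 to compound 3 (0.20 log units; within the scatter).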

Compound 3, half-maximal inhibitory concentration: 550 nM
For compound 3 the middle estimate is 2.5-fold (0.40 log units) below the measured one; measured number inside the range.
By their numbers in this assay, from the lowest: compound 1; then compounds 2 and 3 (each within the scatter of the next).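

In this assay, 2-methoxyphenyl in place of 3,4-difluorophenyl on the sulfonamide nitrogen gives a 1.6-fold higher number from compound 2 to compound 3 (0.20 log units; within the scatter), so these two aryl groups are not separated, although the entering group adds a hydrogen-bond acceptor by count. The step of a 7.1-fold higher number from compound 1 to compound 3 (0.85 log units; beyond the scatter) sets 3-bromophenyl apart from 2-methoxyphenyl as well, and compound 1 alone holds the lowest number of the three. No measurement available here accounts for this order.

Still open, from the compounds shown here alone, is whether 3-methoxyphenyl would fall nearer compound 1 or compound 3. Also open, going by these compounds, is how an aminophenyl or carboxyphenyl group would behave on the same sulfonamide nitrogen.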